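This account rests on a few compounds, and the source may have more. Where it says the series, first, only, none or still open, it means among the compounds named here.

Measured so far in an ADME assay on Huh-7 cells (Homo sapiens) for cytotoxicity; on this read-out lower numbers stand for higher toxicity in this test and higher numbers for lower toxicity in this test:
- compound 1 `Cc1ccccc1-c1nn(-c2cccc(Cl)c2)cc1CNCCN1CCN(C)CC1`: 16000 nM
- compound 2 `CN1CCN(CCNCc2cn(-c3ccc(F)cc3F)nc2C2CCCCC2)CC1`: a limit, > 20000 nM
- compound 3 `CN1CCN(CCNCc2cn(-c3ccc(F)cc3F)nc2-c2ccc(Cl)cc2)CC1`: 19000 nM

Compound 1 stands at the lowest of the two numbers given; the value of compound 3 sits within the usual scatter of it. The value of compound 2 is a limit of the assay, not a number (the limit of > 20000 nM in this assay, at which 1 of the 3 values shown sits). Among the compounds with values here, the only measured step, an at least 1.0-fold lower number from compound 2 to compound 3 (0.02 log units; that floor lies within the scatter), concerns a group on an aromatic carbon and sits on the floor of the scatter.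

Compound 4 `Cc1ccccc1-c1nn(-c2ccc(OC(F)(F)F)cc2)cc1CNCCN1CCN(C)CC1` differs from compound 1 by 4-(trifluoromethoxy)phenyl in place of 3-chlorophenyl on an aromatic nitrogen. Within the data shown here, no measured step changes the group on the aromatic nitrogen, so it offers no direct guide; the one step seen is flat. The step of a 1.1-fold lower number from compound 1 to compound 4 (0.03 log units; within the scatter) is therefore expected to stay within the scatter. Compound 4 is estimated at 15000 nM, with a range from 7000 nM to 20000 nM.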

Compound 4, half-maximal cytotoxic concentration: 17000 nM
Compound 4: the middle estimate sits 1.1-fold (0.05 log units) below what was measured; measured number inside the range.
By their numbers in this assay, from the lowest: compounds 1, 4 and 3 (each within the scatter of the next). At a limit, above all of these: compound 2.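

In this assay, the group on the aromatic nitrogen now has a measured step of its own: a 1.1-fold higher number from compound 1 to compound 4 (0.03 log units; within the scatter). At this place, then, 4-(trifluoromethoxy)phenyl, with its larger heavy-atom count and one hydrogen-bond acceptor, reads the same as 3-chlorophenyl on the core of compound 1. Nothing at hand bears on why this step is flat.

This rests on a single pair, with the 2-methylphenyl group held constant. Open, going by these compounds, is whether an amine or a carboxylic acid on this phenyl ring would move the number beyond the scatter.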